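The source may report more compounds than this note shows. Statements on the series, on what has been measured and on what is new or still open speak of the compounds shown alone.

In an ADME assay on MT4 cells (Homo sapiens) for cytotoxicity, read by MTT assay (a lower number here means that less compound is tolerated, a higher number that more compound is tolerated), compound 2 (`O=C(CSc1nncnc1-c1ccccc1Cl)Nc1ccccc1`) gives 127000 nM, and compound 3 (`CC(=O)c1ccc(NC(=O)CSc2nncnc2-c2cccc3ccccc23)c(Br)c1`) gives 133000 nM, so these two sit level within the usual scatter. Compound 1 (`O=C(CSc1nncnc1-c1ccccc1Cl)c1ccc(Cl)c(Cl)c1`) gives 33000 nM. Among the measured compounds shown here, the only measured step between compounds that differ in one place is a 3.8-fold higher number from compound 1 to compound 2 (0.59 log units; beyond the scatter), a modest change made on a carbonyl carbon.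

The next structure, compound 4 (`COC(=O)c1sccc1NC(=O)CSc1nncnc1-c1ccccc1Cl`), puts 2-(methoxycarbonyl)thiophen-3-yl in place of phenyl on an amide-type nitrogen. For the measured compounds named here, no measured step covers this exact change, since the one available lies at a different place, so it serves only as a rough guide to how large a single change can be here. Compound 3 also has a group other than phenyl on its amide-type nitrogen and differs elsewhere too, and its 133000 nM offers some support for little movement. A small drop or no change beyond the scatter is therefore expected, and the estimated step is a 1.3-fold lower number from compound 2 to compound 4 (0.10 log units; within the scatter). For compound 4 the expected value is 100000 nM, with an estimated range from 35000 nM to 250000 nM.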

Compound 4, half-maximal cytotoxic concentration: 105000 nM
For compound 4 the middle estimate is 1.1-fold (0.02 log units) below the measured one, within the range that was stated.
By their numbers in this assay, from the lowest: compound 1; then compounds 4, 2 and 3 (each within the scatter of the next).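

At the amide-type nitrogen, placing 2-(methoxycarbonyl)thiophen-3-yl where phenyl stood leaves the number in this assay within the scatter (a 1.2-fold lower number from compound 2 to compound 4 (0.08 log units; within the scatter)). Among the compounds shown here, this is the first measured step at this place, and it shows that a group with more heavy atoms, a five-membered aromatic ring and hydrogen-bond acceptors can replace phenyl here without a clear shift, whereas the step at the carbonyl carbon (a 3.8-fold higher number from compound 1 to compound 2 (0.59 log units; beyond the scatter)) lies beyond the scatter. Nothing available explains this result.

For the compounds shown here, with only two groups compared directly at this nitrogen, the result cannot be extended to the position in general. Going by these compounds, it remains open whether a carboxylic acid in place of the methoxycarbonyl group, or a basic amine on the ring, would also leave the number within the scatter.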